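The source may report more compounds than this note shows. Statements on the series, on what has been measured and on what is new or still open speak of the compounds shown alone.

Compound 1 `CC1Cn2cc([N+](=O)[O-])nc2O1`: > 500000 nM
Compound 2 `Cc1ccc(-c2c([N+](=O)[O-])nc3n2CC(C)O3)cc1`: > 125000 nM
Compound 3 `CC1Cn2c(nc([N+](=O)[O-])c2-c2cccc(C#N)c2)O1`: > 500000 nM

All three compounds were tested in an ADME assay on HepG2 cells (Homo sapiens) for cytotoxicity, read by MTT assay, with a stated time of 24 h (on this read-out lower numbers stand for higher toxicity in this test and higher numbers for lower toxicity in this test), and none of them gave a number. Compound 1 sits at the limit of > 500000 nM in this assay, at which 2 of the 3 values shown sit, so its value is a limit of the test, and compound 3 shares that limit. Compound 2 sits at the limit of > 125000 nM in this assay, at which 1 of the 3 values shown sits, which is also a limit.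

Compound 4 `Cc1ccc(-c2c([N+](=O)[O-])nc3n2CC(C)O3)s1` is the next compound to be measured in this assay. It differs from compound 1 by 5-methylthiophen-2-yl in place of hydrogen on an aromatic carbon. Going by the values given here, no two measured compounds differ in one place, so no measured step gives a direct guide to the size of this change.

The closest guide is compound 2, whose reading of > 125000 nM is a limit. On that basis, compound 4 is expected to show little toxicity in this test, and it will most likely return a limit as well. A modest move toward lower numbers is expected, although the limits leave its true size open. The estimated change is an at least 3.3-fold lower number from compound 1 to compound 4 (0.52 log units; beyond the scatter). For compound 4 the expected value is 150000 nM, with an estimated range from 60000 nM to 500000 nM.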

Compound 4, half-maximal cytotoxic concentration: > 250000 nM
Compound 4: a limit, no number (the forecaster's own chance of this, stated with the estimate: 80%); middle value at least 1.6-fold (0.22 log units) from the limit.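

In this assay compound 4 returned a limit and no number: the limit of > 250000 nM in this assay, at which 1 of the 4 values shown sits.

Compound 1 also stands at a limit: the limit of > 500000 nM in this assay, at which 2 of the 4 values shown sit.

The step between compound 1 and compound 4 cannot be read from these two limits. The compounds shown leave open what 5-methylthiophen-2-yl in place of hydrogen on an aromatic carbon does to the read-out, and at what concentration, if any, each compound becomes toxic to these cells.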